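The compounds below may be only part of what the source reports. "The series", "measured", "known", "first", "only" and "open" are said of these compounds alone.

Measured so far:
compound 1, `O=C(N[C@@H]1CNCC[C@H]1c1ccc(Cl)cc1)c1ccc(-c2ncnc3c2CCC3O)s1` — 24100 nM
compound 2, `Cn1ncc(Cl)c1-c1cc(C(=O)N[C@@H]2CN[C@H](CCO)C[C@H]2c2ccc(F)c(F)c2)oc1Cl` — 460 nM
compound 3, `COCC[C@@H]1C[C@@H](c2ccc(Cl)c(Cl)c2)[C@H](NC(=O)c2cc(-c3c(Cl)cnn3C)c(Cl)o2)CN1` — 1060 nM

In a functional assay on OVCAR-8 cells (Homo sapiens) for antiproliferative activity (a higher number here means a weaker inhibitor, a lower number a stronger inhibitor), compound 1 gives 24100 nM. Compound 2 gives 460 nM in this assay, and compound 3 gives 1060 nM. On these numbers compound 3 stands second highest of the three: its nearest neighbour is compound 2, whose lower number lies beyond the usual scatter, and its furthest is compound 1, whose much higher number lies far beyond the scatter. Among the compounds with values here, no two of the three compounds differ in one place only, so no single step between them is counted.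

The next compound to be examined is compound 4, `Cn1ncc(Cl)c1-c1cc(C(=O)N[C@@H]2CN[C@H](CCCO)C[C@H]2c2ccc(Cl)c(Cl)c2)oc1Cl`. It differs from compound 3 in one place:

hydroxymethyl in place of methoxy on a saturated chain carbon, two bonds along the chain from a saturated ring carbon

The two compounds hold the same atoms, joined differently. Within the data shown here, since no step between measured compounds is available, the expectation for this change can rest only on the three values given. Compound 2, which carries a 2-hydroxyethyl chain, gives 460 nM, a lower number than compound 3, though compound 2 also differs elsewhere. On that basis a small step downward is expected from compound 3 to compound 4, a 1.5-fold lower number from compound 3 to compound 4 (0.18 log units; within the scatter), likely within the usual scatter. Compound 4 is therefore estimated at 700 nM, with a range from 300 nM to 1600 nM.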

Compound 4, half-maximal inhibitory concentration: 600 nM
Beside the measured number, compound 4's estimate is 1.2-fold (0.07 log units) above it; low and high end bracket the measured number.
By their numbers in this assay, from the lowest: compounds 2, 4 and 3 (each within the scatter of the next, the first and the last beyond it); then compound 1.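

Within the data shown here, with compound 4, a single change at this position can be read for the first time: hydroxymethyl in place of methoxy on a saturated chain carbon, two bonds along the chain from a saturated ring carbon, gives a 1.8-fold lower number from compound 3 to compound 4 (0.25 log units; within the scatter) in this assay and so does not separate the two compounds. The 2-methoxyethyl chain of compound 3 and the 3-hydroxypropyl chain of compound 4 hold the same atoms, and hydroxymethyl carries a hydrogen-bond donor that methoxy does not, yet this assay does not tell these chains apart on this single pair. Nothing on hand explains this result or tells what lies behind the antiproliferative readings.

The compounds shown leave open how an amine, a carboxylic acid or a longer chain at this position would read in this assay, since a single pair with two neutral chains says little about other groups. They also leave open whether the same exchange of methoxy for hydroxymethyl would give a similarly small step with a different group elsewhere on the shared core.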